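A few compounds are considered here, and "the series" means these few. Any claim that something is new, unique, unknown or untested is made for them only; others in the source may bear on it.

In a functional assay on the whole organism (artery, strain albino) with Rattus norvegicus as the target, with a stated time of 15 min, at a dose of 10 mg/kg by the oral route (on this read-out lower numbers stand for less inhibition and higher numbers for more inhibition at the one dose given (going by the name of the read-out)), compound 1 `CC1=C(C(=O)Nc2ccc(F)cc2)C(c2ccc([N+](=O)[O-])cc2)N=C(SCc2ccccc2)N1` gives 3.1%. Among the compounds with values here, compound 2 `CC1=C(C(=O)Nc2ccc(F)cc2)C(c2ccc([N+](=O)[O-])cc2)N=C(SCc2ccc(F)cc2)N1` gives 3.1% in this assay, and the only single change among the measured pairs, fluoro in place of hydrogen on an aromatic carbon, reads no change at the digits printed from compound 1 to compound 2 (within the scatter). Compound 3 `CC1=C(C(=O)Nc2ccc(Br)cc2)C(c2ccc(Cl)cc2Cl)N=C(SCc2ccccc2)N1` gives 1.5% in this assay; its number is the lowest of the three, yet its gaps to compound 1 and to compound 2 both lie within the scatter, so nothing separates the three compounds on this read-out. Compound 4 `CC1=C(C(=O)Nc2ccc(Br)cc2)C(c2ccc(Cl)cc2Cl)N=C(SCc2cccc(Cl)c2)N1` differs from compound 3 in one place: chloro in place of hydrogen on an aromatic carbon. Within the data shown here, no measured step shows chloro entering an aromatic carbon; the one step measured, from compound 1 to compound 2, puts a fluoro onto the benzyl group and stays within the scatter. On that single comparison, compound 4 is expected to give 2.5% in this assay, with a range from -5% to 12%. The step expected is a number 1 percentage points higher from compound 3 to compound 4 (within the scatter), none beyond the scatter.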

Compound 4, a percentage reported as inhibition, in the whole organism at one dose (the size of the read-out at that dose, not a potency): 1.5%
Beside the measured number, compound 4's estimate is 1 percentage points above it; low and high end bracket the measured number.
By their numbers in this assay, from the lowest: compounds 3, 4, 1 and 2 (each within the scatter of the next).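

In this assay, the change from benzylsulfanyl to (3-chlorobenzyl)sulfanyl reads no change at the digits printed from compound 3 to compound 4 (within the scatter), which gives the first measured result for chloro on an aromatic carbon of the benzyl group, meta to a large group. Together with the fluoro change on the benzyl group, which reads no change at the digits printed from compound 1 to compound 2 (within the scatter), it means that neither single substitution measured on this group moves the number beyond the scatter, and the two steps were measured on different backgrounds. Nothing measured here offers an explanation for this result.

As far as these compounds go, what an amine, a carboxylic acid or a longer chain at this place would do remains open. The single oral dose also leaves open whether compound 3 and compound 4 would stay level at another dose.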